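The source may hold more compounds than are shown below. What is called first, only, known or untested is meant among the compounds shown, and "the series" means these compounds.

Measured so far in a functional assay on HepG2 cells (Homo sapiens) for antiproliferative activity, read by spectrophotometry, with a stated time of 2 days; a higher number here means a weaker inhibitor of growth, a lower number a stronger inhibitor of growth:
- Compound 1 `CC(=O)N1CCN(c2ccc(Nc3ncc(C(F)(F)F)c(N4Cc5cccc(N(C)S(C)(=O)=O)c5C4)n3)cc2)CC1` gives 1400 nM
- Compound 2 `COc1cc(N2CCN(C(C)=O)CC2)ccc1Nc1ncc(C(F)(F)F)c(N2Cc3cccc(N(C)S(C)(=O)=O)c3C2)n1` gives 3800 nM
- Compound 3 `COc1cc(Nc2ncc(C(F)(F)F)c(N3Cc4cccc(N(C)S(C)(=O)=O)c4C3)n2)c(OC)cc1Cl` gives 25600 nM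

Compound 1 holds the lowest of these three numbers, and its gap to each of the other two lies beyond the scatter. Compound 4 `CN(c1cccc2c1CN(c1nc(Nc3ccc(Nc4ccccc4)cc3)ncc1C(F)(F)F)C2)S(C)(=O)=O` has not yet been measured. It carries anilino in place of 4-acetylpiperazin-1-yl on an aromatic carbon, para to a large group, and the difference is anilino in place of 4-acetylpiperazin-1-yl on an aromatic carbon.

Within the data shown here, no measured step makes this exchange. Among the measured compounds shown here, the one measured step is a 2.7-fold higher number from compound 1 to compound 2 (0.43 log units; beyond the scatter), a methoxy in place of hydrogen, so it shows only that a single change on this ring can shift the number modestly. Compound 3 also lacks the 4-acetylpiperazin-1-yl group, but it differs in other ways too. Its value of 25600 nM is therefore only a loose hint towards a higher number. A moderate rise is expected, with wide uncertainty. The expected step is a 2.9-fold higher number from compound 1 to compound 4 (0.46 log units; beyond the scatter). Compound 4 is estimated at 4000 nM, with an expected range of 900 nM to 18000 nM.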

Compound 4, concentration for 50% growth inhibition: 8600 nM
The estimate for compound 4 lay 2.2-fold (0.33 log units) below the measured number; measured number inside the range.
By their numbers in this assay, from the lowest: compound 1; then compound 2; then compound 4; then compound 3.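

In this assay, among these compounds, the exchange of 4-acetylpiperazin-1-yl for anilino on an aromatic carbon, para to a large group, gives a 6.1-fold higher number from compound 1 to compound 4 (0.79 log units; beyond the scatter), the first direct reading of a change of this substituent rather than of a methoxy added to the ring. Compound 4 still gives a measured 8600 nM, so growth inhibition in this assay does not depend on keeping the 4-acetylpiperazin-1-yl group, although the step runs towards a weaker inhibitor. The step reads the swap only as a whole: a non-aromatic ring with hetero atoms leaves, an aromatic carbon ring and a hydrogen-bond donor enter, and their shares cannot be separated.

Nothing available bears on the reason for this rise. Going by these compounds, it remains open how a morpholin-4-yl group or an unacylated piperazin-1-yl group would behave at this place, and either would help separate the ring from the acetyl.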